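This account rests on a few compounds, and the source may have more. Where it says the series, first, only, none or still open, it means among the compounds named here.

Measured so far:
compound 1, `Cc1ccc2nc(-c3cccc(OC(F)(F)F)c3)[nH]c(=O)c2c1`, 0%
compound 2, `Cc1ccc2nc(-c3ccccc3C(F)(F)F)[nH]c(=O)c2c1`, 21.1%
compound 3, `Cc1ccc2c(=O)[nH]c(-c3ccccc3OC(F)(F)F)nc2c1`, 100%

In an assay on isolated protein for inhibition of DNA topoisomerase 1 (Homo sapiens), with a stated time of 30 min, tested at 20 uM (a lower number here means a weaker effect, a higher number a stronger effect of the compound at the concentration tested), compound 2 stands second highest of the three numbers shown. Its nearest neighbour is compound 1, which in this assay gives a number lower by a margin beyond the usual scatter; the furthest is compound 3, whose number lies far higher, also beyond the scatter.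

The step considered here leads from compound 2 to compound 4, `Cc1ccc2nc(-c3ccccc3OC(F)(F)F)[nH]c(=O)c2c1`, which has not yet been measured. The structural change is trifluoromethoxy in place of trifluoromethyl on an aromatic carbon. The group that enters, trifluoromethoxy, is also carried by compound 3 and by compound 1, and those two compounds give the highest and the lowest numbers of the set, so the measured compounds alone do not fix the direction of the step. Among the measured compounds shown here, no step between measured compounds that differ in one place is available.

Given that compound 3 also bears a trifluoromethoxy group and gives 100%, a rise in this assay from compound 2 to compound 4 of about a number 33.9 percentage points higher from compound 2 to compound 4 (beyond the scatter) is expected, beyond the scatter but uncertain in size. Compound 4 is therefore estimated at 55% in this assay, within a range from 15% to 95%.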

Compound 4, a percentage reported as inhibition, at one concentration (the size of the read-out at that concentration, not a potency): 0%
Estimate against measurement, compound 4: 55 percentage points above; the whole stated range lies above it.
By their numbers in this assay, from the lowest: compounds 1 and 4 (each within the scatter of the next); then compound 2; then compound 3.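

In this assay, among the compounds shown here, the exchange of trifluoromethyl for trifluoromethoxy on an aromatic carbon ortho to a large group gives a number 21.1 percentage points lower from compound 2 to compound 4 (beyond the scatter) and so provides the first direct reading of this change. With the methyl group placed as in compound 2, trifluoromethoxy does not reproduce the high number seen for compound 3: compound 4 gives 0% and compound 3, which carries the same group at the same place on its aromatic ring, gives 100% with the methyl group sitting elsewhere on the shared core. The printed values therefore show that trifluoromethoxy alone does not set the read-out, and compound 1 and compound 4, which differ in where that group sits, lie within the scatter of each other.

Still open, as far as these compounds go, is whether an amine, a carboxylic acid or a longer chain such as ethoxy at this place would restore any of the effect, and whether moving the methyl group of compound 2 to its place in compound 3 would raise the number as well. Nothing shown here bears on why the step from trifluoromethyl to trifluoromethoxy goes in this direction.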